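A few compounds are considered here, and "the series" means these few. Any claim that something is new, unique, unknown or untested is made for them only; others in the source may bear on it.

Measured so far in an ADME assay on microsomes from liver (Homo sapiens) for metabolic stability; on this read-out lower numbers stand for a shorter-lived compound and higher numbers for a longer-lived compound:

- compound 1 `CC(C)[C@@H](C[C@H]1SC(=O)NC1=O)c1ccc(-c2ccc3cccc(F)c3c2)[nH]c1=O` gives 1.24 h.
- compound 2 `CC(C)[C@@H](c1ccc(-c2ccc3cccc(F)c3c2)[nH]c1=O)[C@H]1OC(=O)NC1=O` gives only a limit of this assay, > 3 h.
- compound 3 `CC(C)C(c1ccc(-c2ccc3cccc(F)c3c2)[nH]c1=O)C1SC(=O)NC1=O` gives 1.87 h.

Compound 3 holds the higher of the two plain numbers, yet the gap to compound 1 sits within the usual scatter, so the two cannot be ranked against each other. The third result is the limit of > 3 h in this assay, at which 1 of the 3 values shown sits.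

Compound 4 `CC(C)C(c1ccc(-c2ccc3cccc(F)c3c2)[nH]c1=O)C1NC(=O)NC1=O` is the next candidate. It differs from compound 3 in one place: 2,5-dioxoimidazolidin-4-yl in place of 2,4-dioxo-1,3-thiazolidin-5-yl on a saturated chain carbon bound to an aromatic carbon and a saturated chain carbon. Among the compounds with values here, no measured pair shows this exchange, so the expectation rests on the shared core alone. A modest lengthening in this assay is expected, a 1.2-fold higher number from compound 3 to compound 4 (0.09 log units; within the scatter), though a step hidden in the scatter is equally plausible. Compound 4 is thus estimated at 2.3 h, between 1.2 h and 4.5 h.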

Compound 4, half-life: 0.578 h
Estimate against measurement, compound 4: 4.0-fold (0.60 log units) above; the whole stated range lies above it.
By their numbers in this assay, from the lowest: compound 4; then compounds 1 and 3 (each within the scatter of the next). At a limit, above all of these: compound 2.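

In this assay, within the data shown here, this is the first exchange at this place that can be read on its own: 2,5-dioxoimidazolidin-4-yl in place of 2,4-dioxo-1,3-thiazolidin-5-yl gives a 3.2-fold lower number from compound 3 to compound 4 (0.51 log units; beyond the scatter) and so shortens the half-life. Both rings are five-membered and non-aromatic, so the half-life here depends on more than ring size and on the identity of the ring itself. The results shown give no reason for this drop.

Going by these compounds, whether a carboxylic acid or an open-chain amide on the same saturated chain carbon would give a longer or shorter half-life remains open. A single exchange also cannot show whether this drop would recur on a different core.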